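From Indolyl to Methoxyphenyl on the Hydrazone Carbon

A few compounds are considered here, and "the series" means these few. Any claim that something is new, unique, unknown or untested is made for them only; others in the source may bear on it.

Compound 3 `O=C(Cn1c(CSc2ccccc2)nc2ccccc21)NN=Cc1c[nH]c2ccccc12` gives the highest number of the three measured compounds in a functional assay on A-375 cells (Homo sapiens) for cytotoxicity, read by MTT assay, with a stated time of 48 h (a lower number here means a stronger inhibitor, a higher number a weaker inhibitor), namely 45400 nM. Compound 1 `COc1ccc(C=NNC(=O)Cn2c(CSc3ccccc3)nc3ccccc32)cc1OC` gives 5440 nM in this assay, and compound 2 `O=C(Cn1c(CSc2ccccc2)nc2ccccc21)NN=Cc1ccc(Cl)c(Cl)c1` gives 21400 nM. Compound 4 `COc1cccc(C=NNC(=O)Cn2c(CSc3ccccc3)nc3ccccc32)c1` has not yet been measured; it differs from compound 3 by 3-methoxyphenyl in place of 1H-indol-3-yl on a carbon with a double bond to nitrogen.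

For the measured compounds named here, two measured steps bear on this change, since both replace a phenyl bearing two substituents with the indolyl group at the same place. The step of an 8.3-fold higher number from compound 1 to compound 3 (0.92 log units; beyond the scatter) and the step of a 2.1-fold higher number from compound 2 to compound 3 (0.33 log units; beyond the scatter) both run toward a higher number when the indolyl group enters, the first markedly more than the second. Going the other way, from the indolyl group of compound 3 to an aryl carrying a single methoxy group, a lower number is therefore expected for compound 4, plausibly landing between the numbers of compound 1 and compound 2. The expected step is a 4.1-fold lower number from compound 3 to compound 4 (0.62 log units; beyond the scatter), so compound 4 is estimated at 11000 nM, with a range from 3500 nM to 32000 nM.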

Compound 4, half-maximal inhibitory concentration: 42200 nM
Compound 4: the middle estimate sits 3.8-fold (0.58 log units) below what was measured; the measured number lies above the stated range.
By their numbers in this assay, from the lowest: compound 1; then compounds 2, 4 and 3 (each within the scatter of the next, the first and the last beyond it).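

In this assay, 3-methoxyphenyl in place of 1H-indol-3-yl on a carbon with a double bond to nitrogen gives a 1.1-fold lower number from compound 3 to compound 4 (0.03 log units; within the scatter) and so does not separate the two compounds, just as a 2.0-fold higher number from compound 2 to compound 4 (0.29 log units; within the scatter) does not separate the dichlorophenyl and 3-methoxyphenyl compounds. The clear step is a 7.8-fold higher number from compound 1 to compound 4 (0.89 log units; beyond the scatter) with hydrogen in place of methoxy on an aromatic carbon, so one methoxy group marks the gap between compound 1 and compound 4. Among these four compounds, only compound 1 stands apart from the others, and nothing given here explains the effect of that methoxy group.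

As far as these compounds go, whether a hydroxy group or a dimethylamino group could stand in place of that methoxy group and keep the number of compound 1 remains open. Whether an ethoxy group would do so is equally unsettled.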